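Removing the iodo group from compound 3

The compounds below may be only part of what the source reports. "The series", "measured", "known", "first", "only" and "open" are said of these compounds alone.

In a functional assay on OVCAR-5 cells (Homo sapiens) for inhibition, with a stated time of 48 h, tested at 50 uM (on this read-out lower numbers stand for less inhibition of growth and higher numbers for more inhibition of growth at the one concentration tested), compound 3 `CC[C@](C)(CCCC(C)C)CCc1ccc(O)c(I)c1` gives 11%. That lies within the scatter of compound 2 `C=C[C@@](C)(/C=C/c1ccc(OC(=O)CCCCC)cc1)CCC=C(C)C` at 13% and clearly under compound 1 `C=C[C@@](C)(/C=C/c1ccc(OC(=O)CCC)cc1)CCC=C(C)C` at 41%.

Compound 4 `CC[C@](C)(CCCC(C)C)CCc1ccc(O)cc1` differs from compound 3 in one place, with hydrogen in place of iodo on an aromatic carbon. Going by the values given here, no measured pair shows this change. Among the compounds with values here, the only measured step, a number 28 percentage points lower from compound 1 to compound 2 (beyond the scatter), sits elsewhere, on a saturated chain carbon. It shows that a single change moved this read-out beyond the scatter in that pair, but it says nothing about direction at the aromatic carbon.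

With compound 3 at 11%, the number has little room to fall and more room to rise. The estimated change, a number 9 percentage points higher from compound 3 to compound 4 (within the scatter), is therefore small, and its direction remains uncertain. For compound 4 the expected value is 20%, with an estimated range from 5% to 45%.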

Compound 4, percent growth inhibition at one concentration: 43%
Compound 4: the middle estimate sits 23 percentage points below what was measured; the range from low to high includes it.
By their numbers in this assay, from the lowest: compounds 3 and 2 (each within the scatter of the next); then compounds 1 and 4 (each within the scatter of the next).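

Replacing the iodo group with hydrogen on this aromatic carbon, ortho to a hydroxy group, gives a number 32 percentage points higher from compound 3 to compound 4 (beyond the scatter) in this assay, so a change of a single atom at this position is enough to shift growth inhibition clearly. Going by these compounds alone, this is the first measured change on the aromatic ring, and in this pair the compound carrying iodo shows less inhibition of growth than the one carrying hydrogen at the one concentration tested. Nothing available explains why the two compounds differ.

On these data alone, only iodo and hydrogen can be compared at this carbon, so it remains open where a fluoro, chloro or methoxy group would fall. As far as these compounds go, it is also open whether an amine in place of the hydroxy group would keep the level of inhibition seen with compound 4.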